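This account rests on a few compounds, and the source may have more. Where it says the series, first, only, none or still open, it means among the compounds named here.

Of the compounds shown here, two have been measured so far. Compound 1 `CC(C)(C)c1ccc(OC(C)(C)C2OCC(C/C=C\CCC(=O)O)C(c3cccnc3)O2)cc1` is the weaker of the pair: in an assay for inhibition of Thromboxane-A synthase (Homo sapiens), using microsomes (on this read-out lower numbers stand for stronger inhibition and higher numbers for weaker inhibition), compound 1 gives 280 nM. Compound 2 `CC(C)(Oc1ccccc1O)C1OCC(C/C=C\CCC(=O)O)C(c2cccnc2)O1` differs from it only in the aryl group attached through an oxygen on a saturated carbon, and in this assay compound 2 gives 32 nM. Among the measured compounds shown here, the step of an 8.8-fold lower number from compound 1 to compound 2 (0.94 log units; beyond the scatter) thus places compound 2 at the lowest number of the two, with compound 1 as its only neighbour.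

The next compound, compound 3 `CC(C)(Sc1ccccc1)C1OCC(C/C=C\CCC(=O)O)C(c2cccnc2)O1`, carries the change (phenylsulfanyl in place of 2-hydroxyphenoxy on a saturated chain carbon bound to two saturated chain carbons and a saturated ring carbon). For the measured compounds named here, the only measured step that touches this part of the molecule is the one from compound 1 to compound 2, which was of modest size; that step, however, only shows that the aryl group here can shift the number markedly, and it does not contain a sulfur-linked ring, so it gives no direct guide to the direction. With the hydroxyl gone and the linking atom changed, a move back toward weaker inhibition is expected, of about a 3.8-fold higher number from compound 2 to compound 3 (0.57 log units; beyond the scatter). Compound 3 is therefore estimated at 120 nM, within a range from 40 nM to 400 nM.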

Compound 3, half-maximal inhibitory concentration: 40 nM
Estimate against measurement, compound 3: 3.0-fold (0.48 log units) above; the measured number falls inside the stated range.
By their numbers in this assay, from the lowest: compounds 2 and 3 (each within the scatter of the next); then compound 1.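

In this assay the exchange of 2-hydroxyphenoxy, which carries a hydrogen-bond donor, for phenylsulfanyl, which carries none, gives a 1.3-fold higher number from compound 2 to compound 3 (0.10 log units; within the scatter), so the two groups cannot be told apart at this position and neither the hydroxyl nor the linking oxygen is required for a number at this level. The step of a 7.0-fold lower number from compound 1 to compound 3 (0.85 log units; beyond the scatter) shows that the distance from compound 1 is not tied to the hydroxyl, since an aromatic ring with no substituent, joined through sulfur, also lies well on the low side; because the linking atom and the tert-butyl group change together in this step, the two contributions cannot be separated. Nothing at hand explains why these two different groups give numbers within the scatter of each other.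

From the compounds shown here alone, what a plain phenoxy group would give stays open, and with it the separate contributions of the hydroxyl and the linking atom. Also open, going by these compounds, is whether a 4-(tert-butyl)phenylsulfanyl group would return the number toward that of compound 1, and how a group with no aromatic ring, such as a simple amine, would fare on this saturated chain carbon.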